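This account rests on a few compounds, and the source may have more. Where it says the series, first, only, none or still open, it means among the compounds named here.

The shared core of compound 1 `Cc1ccccc1-c1noc(-c2ccc(C3CCCCC3)cc2)n1` carries, in compound 2 `Cc1cc(CC(=O)O)ccc1-c1noc(-c2ccc(C3CCCCC3)cc2)n1`, a carboxymethyl group in place of a hydrogen on an aromatic carbon. In a functional assay on CHO cells with sphingosine 1-phosphate receptor 4 (Homo sapiens) as the target, read by GTPgammaS binding (a lower number here means that less compound is needed, a higher number that more compound is needed for the effect), compound 1 reaches only the limit of > 10000 nM. Compound 2 likewise stops at the limit of > 10000 nM. Compound 3 `Cc1cc(CCC(=O)O)ccc1-c1noc(-c2ccc(OCC(F)(F)F)c(C#N)c2)n1`, with a different substituent on the shared core, also gives only the limit of > 10000 nM. The step that the two limits leave unreadable from compound 1 to compound 2 is unreadable; both of its values are limits. Compound 2 thus stands at the ceiling of the assay together with every other value shown, as the limit of > 10000 nM in this assay, at which 3 of the 3 values shown sit, records. Compound 4 `Cc1cc(CCCC(=O)O)ccc1-c1noc(-c2ccc(C3CCCCC3)cc2)n1` differs from compound 2 by 2-carboxyethyl in place of carboxy on a saturated chain carbon bound to an aromatic carbon, the acid carried further out on a longer chain. Within the data shown here, no measured step shows a readable effect of chain length, and the one measured step is hidden by the limits, so nothing in these data points to a gain in this assay. The expected step of a number no higher from compound 2 to compound 4 (the limit leaves the size open) is therefore none beyond the scatter, with a sizeable chance of another limit. Compound 4 is expected at 10000 nM in this assay, within a range of 3000 nM to 30000 nM.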

Compound 4, half-maximal effective concentration: > 10000 nM
Compound 4: only a limit was reported (the forecaster's own chance of this, stated with the estimate: 70%); the middle value sits exactly at the limit.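

In this assay, among these compounds, compound 4 gives > 10000 nM, which is a limit, so no step from compound 1 or compound 2 to compound 4 can be read. Compound 4 joins compounds 1, 2 and 3 at one reading: the limit of > 10000 nM in this assay, at which 4 of the 4 values shown sit.

The compounds shown leave open whether any chain length or other group on the shared core gives a measurable value in this assay.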